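A cyclobutyl for propyl swap on a carbonyl carbon

A few compounds are considered here, and "the series" means these few. Any claim that something is new, unique, unknown or untested is made for them only; others in the source may bear on it.

In a functional assay on SK-BR-3 cells (Homo sapiens) for antiproliferative activity (on this read-out higher numbers stand for weaker inhibition and lower numbers for stronger inhibition), compound 3 `CCCC(=O)Nc1cc2ccc(O[C@@H]3OC(C)(C)[C@H](OC)[C@@H](O)[C@H]3O)c(C)c2oc1=O` gives 313000 nM, the highest number of the three measured and so the weakest inhibitor among them. Compound 1 `CO[C@@H]1[C@@H](O)[C@@H](O)[C@H](Oc2ccc3cc(NC(=O)C4CCCC4)c(=O)oc3c2C)OC1(C)C` gives 67000 nM and compound 2 `CCCCC(=O)Nc1cc2ccc(O[C@@H]3OC(C)(C)[C@H](OC)[C@@H](O)[C@H]3O)c(C)c2oc1=O` gives 118000 nM, two values within the scatter of each other. The next compound, compound 4 `CO[C@@H]1[C@@H](O)[C@@H](O)[C@H](Oc2ccc3cc(NC(=O)C4CCC4)c(=O)oc3c2C)OC1(C)C`, carries cyclobutyl in place of propyl on a carbonyl carbon. Among the compounds with values here, three measured steps bear on this change. The closest is the one between cyclopentyl and propyl, a 4.7-fold higher number from compound 1 to compound 3 (0.67 log units; beyond the scatter). The step between butyl and propyl points the same way, a 2.7-fold higher number from compound 2 to compound 3 (0.42 log units; beyond the scatter). The step between cyclopentyl and butyl, a 1.8-fold higher number from compound 1 to compound 2 (0.25 log units; within the scatter), stays small. Propyl thus goes with the highest number so far, and compound 4 shares a carbon ring with compound 1, so a modest fall is expected rather than none. The expected change is a 2.8-fold lower number from compound 3 to compound 4 (0.45 log units; beyond the scatter). For compound 4 the estimated value is 110000 nM, with an expected range from 45000 nM to 250000 nM.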

Compound 4, half-maximal inhibitory concentration: 220000 nM
For compound 4 the middle estimate is 2.0-fold (0.30 log units) below the measured one, and the stated range covers the measured number.
By their numbers in this assay, from the lowest: compounds 1, 2, 4 and 3 (each within the scatter of the next, the first and the last beyond it).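

In this assay, the four-membered ring on the carbonyl carbon barely separates compound 4 from the open chains: the swap for propyl gives (a 1.4-fold lower number from compound 3 to compound 4 (0.15 log units; within the scatter)) and the swap for butyl gives (a 1.9-fold higher number from compound 2 to compound 4 (0.27 log units; within the scatter)). Carrying a carbon ring therefore does not by itself place compound 4 with compound 1, since the change from cyclopentyl to cyclobutyl gives (a 3.3-fold higher number from compound 1 to compound 4 (0.52 log units; beyond the scatter)), a gap that the open-chain butyl of compound 2 does not show. No measurement here accounts for why these groups differ as they do.

What the compounds shown leave open is whether the trend among the carbon rings continues with cyclohexyl or a phenyl ring on the carbonyl carbon. They also leave open how a longer chain, or a chain ending in an amine, would read.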